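From neopentyl to furan-2-yl on a carbonyl carbon

The compounds below may be only part of what the source reports. "The series", "measured", "known", "first", "only" and "open" are said of these compounds alone.

In a functional assay on MCF7 cells (Homo sapiens) for antiproliferative activity, read by fluorescence, with a stated time of 3 days (a higher number here means a weaker inhibitor, a lower number a stronger inhibitor), compound 1 `CCCCCSc1nc(OC(=O)CC(C)(C)C)c2cn[nH]c2n1` gives 18900 nM as its reading. In this assay compound 2 `Clc1ccccc1Nc1nc(SCCc2ccccc2)nc2[nH]ncc12` gives 19200 nM and compound 3 `O=[N+]([O-])c1cccc(Nc2nc(SCCc3ccccc3)nc3[nH]ncc23)c1` gives 19200 nM as theirs. These three numbers lie within the scatter of one another, so compound 1 stands level with the other two and they cannot be ranked.

Compound 4 `CCCCCSc1nc(OC(=O)c2ccco2)c2cn[nH]c2n1` has not yet been measured. It differs from compound 1 by a single swap, furan-2-yl in place of neopentyl on a carbonyl carbon and so furan-2-yl takes the place of neopentyl on a carbonyl carbon, bringing in a five-membered aromatic ring.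

Within the data shown here, the one measured step between close relatives is no change at the digits printed from compound 2 to compound 3 (within the scatter) and it sits at another place, on a nitrogen on an aromatic ring, so it bears on this swap only weakly. Among the measured compounds shown here, no measured pair shows what a change on the carbonyl carbon does. With so little to go on, no shift beyond the scatter is expected in this assay for this swap, and the range has to stay wide. For the measured compounds named here, the estimated change is a 1.1-fold lower number from compound 1 to compound 4 (0.02 log units; within the scatter) and it amounts to no real step. For compound 4 the expected value is 18000 nM with an estimated range from 7000 nM to 40000 nM in this reading.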

Compound 4, half-maximal inhibitory concentration: 18900 nM
Compound 4: the middle estimate sits 1.1-fold (0.02 log units) below what was measured, and the stated range covers the measured number.
By their numbers in this assay, from the lowest: compounds 1, 4, 2 and 3 (each within the scatter of the next).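

Among these compounds, putting furan-2-yl in place of neopentyl on a carbonyl carbon gives, in this assay, no change at the digits printed from compound 1 to compound 4 (within the scatter), and this is the first measured pair to speak to this position, since the earlier step sat on a nitrogen on an aromatic ring. The pair shows that, in this reading, a group with no ring and a five-membered aromatic ring with a hydrogen-bond acceptor cannot be told apart at this place on the shared core. No supporting evidence is available that would explain why the two groups read alike.

From the compounds shown here alone, only these two groups have been compared on the carbonyl carbon, so it remains open whether an amine, a carboxylic acid or a longer chain there would move the number beyond the scatter. Going by these compounds, it also remains open whether furan-2-yl and neopentyl would still read alike if the pentyl chain on the sulfur were replaced by another group, such as the 2-phenylethyl chain carried by compound 2 and compound 3.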